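Aryl swaps on the shared core: from compound 3 to compound 4

The source may report more compounds than this note shows. Statements on the series, on what has been measured and on what is new or still open speak of the compounds shown alone.

Compound 3 `O=C(O)Cc1sc(C(c2ccc(F)cc2)c2ccc(F)cc2)nc1-c1cccc(F)c1` carries 3-fluorophenyl on the shared core; in an in vitro functional assay on HEK285-7 cells for antagonist activity at prostaglandin D2 receptor 2 (Homo sapiens), read by BRET and beta-arrestin recruitment (on this read-out higher numbers stand for larger maximal responses and lower numbers for smaller maximal responses), compound 3 gives 80%. Compound 1 `O=C(O)Cc1sc(C(c2ccc(F)cc2)c2ccc(F)cc2)nc1-c1ccnc(F)c1` gives 80% in this assay, and compound 2 `O=C(O)Cc1sc(C(c2ccc(F)cc2)c2ccc(F)cc2)nc1-c1ccco1` gives 80%. The three measured steps are all aryl swaps at the same carbon: no change at the digits printed from compound 1 to compound 2 (within the scatter), no change at the digits printed from compound 1 to compound 3 (within the scatter) and no change at the digits printed from compound 2 to compound 3 (within the scatter). Compound 3 therefore stands level with compounds 1 and 2 on the maximal response, and no one of the three can be set apart from the others.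

Compound 4 `Cc1cc(-c2nc(C(c3ccc(F)cc3)c3ccc(F)cc3)sc2CC(=O)O)ccn1` is the next change at that carbon: 2-methylpyridin-4-yl in place of 3-fluorophenyl on an aromatic carbon. All three measured steps bear on it, since each exchanges one aryl group for another at this position, and each stayed within the scatter. Going by the values given here, a pyridine with a methyl group has not been measured yet, but nothing among the measured steps suggests that a further aryl swap here moves the maximal response.

Compound 4 is expected to sit level with compound 3, with the step of no change at the digits printed from compound 3 to compound 4 (within the scatter) expected to fall within the scatter. The estimate for compound 4 in this assay is 80%, with a range from 66% to 92%.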

Compound 4, largest response reached (reported as efficacy), in percent of the reference or control that the assay uses: 80%
Compound 4: the middle estimate sits on the measured number at the digits printed, within the range that was stated.
By their numbers in this assay, from the lowest: compounds 1, 2, 3 and 4 (each within the scatter of the next).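

In this assay, 2-methylpyridin-4-yl in place of 3-fluorophenyl adds a ring nitrogen and 1 hydrogen-bond acceptor, yet gives no change at the digits printed from compound 3 to compound 4 (within the scatter), and in place of furan-2-yl it gives no change at the digits printed from compound 2 to compound 4 (within the scatter). Methyl in place of fluoro on the pyridine ring gives no change at the digits printed from compound 1 to compound 4 (within the scatter), so the maximal response also holds when the substituent on that ring is exchanged, and all four aryl groups at this carbon remain level. No independent measurement bears on this flat result.

From the compounds shown here alone, whether a saturated ring such as cyclohexyl, or an aryl group carrying an amine or a carboxylic acid, would move the maximal response at this carbon stays open. Also open, going by these compounds, is whether a longer chain in place of the carboxymethyl group would do so.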